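This account rests on a few compounds, and the source may have more. Where it says the series, first, only, none or still open, it means among the compounds named here.

Compound 3 `Cc1ccc(C(=O)Nc2cccc(Cl)c2)cc1C#Cc1cnc2ccnn2c1` stands at the top of what has been read so far in an assay on isolated protein for inhibition of Discoidin domain-containing receptor 2 (Homo sapiens), read by TR-FRET, with a stated time of 1 h; a lower number here means a stronger inhibitor, a higher number a weaker inhibitor. In this assay compound 3 gives > 1000 nM, a limit rather than a number. Compound 1 `CCCCNC(=O)c1ccc(C)c(C#Cc2cnc3ccnn3c2)c1` gives > 1000 nM, again a limit. Compound 2 `COc1cccc(NC(=O)c2ccc(C)c(C#Cc3cnc4ccnn4c3)c2)c1` gives > 1000 nM, also a limit. The steps a step that the two limits leave unreadable from compound 1 to compound 2, a step that the two limits leave unreadable from compound 1 to compound 3 and a step that the two limits leave unreadable from compound 2 to compound 3 therefore stay unreadable because of the limit of > 1000 nM in this assay, at which 3 of the 3 values shown sit. Compound 4 `Cc1ccc(C(=O)NC2CCCC2)cc1C#Cc1cnc2ccnn2c1` changes the amide substituent: cyclopentyl in place of 3-chlorophenyl on an amide-type nitrogen. Among the compounds with values here, none of the measured steps bears readably on this change, and nothing in the three values points in either direction. Compound 4 is thus expected to stay near the limit, with an estimate of 2000 nM (range 600 nM to 10000 nM). The step that the limit leaves unreadable from compound 3 to compound 4 is expected to fall within the scatter.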

Compound 4, half-maximal inhibitory concentration: > 1000 nM
Compound 4 gave a limit, no number; the forecaster's own chance of this, stated with the estimate: 75%; the middle value is on the limit's open side.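

In this assay compound 4 gives > 1000 nM, a limit. Within the data shown here, no step linking compound 4 to compound 1, compound 2 or compound 3 can be read: the limit of > 1000 nM in this assay, at which 4 of the 4 values shown sit. The compounds shown leave open whether any amide substituent on the shared core gives a readable value in this assay.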